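This account rests on a few compounds, and the source may have more. Where it says the series, first, only, none or still open, it means among the compounds named here.

- compound 1 `CC(C)c1n[nH]c2c(NCc3ccc(-c4ccccn4)cc3)nc(SCCO)nc12`: 48 nM
- compound 2 `CC(C)c1n[nH]c2c(NCc3ccc(-c4ccccn4)cc3)nc(SCC3CNC(=O)O3)nc12`: 80 nM
- compound 3 `CC(C)c1n[nH]c2c(NCc3ccc(-c4ccccn4)cc3)nc(SCC(O)C(F)(F)F)nc12`: not yet measured

In a functional assay on HT cells (Homo sapiens) for antiproliferative activity, read by fluorescence, with a stated time of 72 h (on this read-out lower numbers stand for stronger inhibition of growth and higher numbers for weaker inhibition of growth), compound 2 gives 80 nM, within the scatter of compound 1 at 48 nM, so the two are not separated. The next change is 2,2,2-trifluoro-1-hydroxyethyl in place of 2-oxo-1,3-oxazolidin-5-yl on a saturated chain carbon bound to a sulfur: 2,2,2-trifluoro-1-hydroxyethyl in place of 2-oxo-1,3-oxazolidin-5-yl. Among the measured compounds shown here, the only measured step at this place is a 1.7-fold higher number from compound 1 to compound 2 (0.22 log units; within the scatter), which is small. No step beyond the scatter is therefore expected in this assay. The expected change is a 1.3-fold lower number from compound 2 to compound 3 (0.12 log units; within the scatter). For compound 3 the estimated value is 60 nM, with an expected range of 25 nM to 150 nM.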

Compound 3, concentration for 50% growth inhibition: 690 nM
Compound 3: middle estimate off by 12-fold (1.06 log units), on the low side, and the stated range ends below it.
By their numbers in this assay, from the lowest: compounds 1 and 2 (each within the scatter of the next); then compound 3.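

In this assay this position, on a saturated chain carbon bound to a sulfur, does not accept every change: the earlier pair stayed within the scatter, but 2,2,2-trifluoro-1-hydroxyethyl in place of 2-oxo-1,3-oxazolidin-5-yl gives an 8.6-fold higher number from compound 2 to compound 3 (0.94 log units; beyond the scatter) beyond it. Trifluoromethyl in place of hydrogen gives a 14-fold higher number from compound 1 to compound 3 (1.16 log units; beyond the scatter) as its step, so keeping the hydroxyl does not by itself hold the activity. Nothing available explains this loss.

Open, on these data alone, is whether a smaller group such as methyl in place of trifluoromethyl would give the same loss. Also open, as far as these compounds go, is how an amine or a carboxylic acid in place of the hydroxyl would read.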